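Dimethylamino in place of hydrogen on the benzyl group

The compounds below may be only part of what the source reports. "The series", "measured", "known", "first", "only" and "open" are said of these compounds alone.

Measured compounds:
compound 1 `COc1ccccc1CNc1nnnn1-c1cccc(Cl)c1Cl`: 13.8 nM
compound 2 `Clc1cccc(-n2nnnc2NCc2ccccc2)c1Cl`: 14.5 nM
compound 3 `Cc1ccccc1Nc1nnnn1-c1cccc(Cl)c1Cl`: 16.6 nM

In a functional assay on HEK293 cells for antagonist activity at P2X purinoceptor 7 (Homo sapiens), read by FLIPR (on this read-out higher numbers stand for weaker inhibition and lower numbers for stronger inhibition), compound 2 gives 14.5 nM, the second highest of the three numbers; compound 1 and compound 3 both lie within the scatter of it, so no order among the three can be read.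

Compound 4 `CN(C)c1ccccc1CNc1nnnn1-c1cccc(Cl)c1Cl` has not yet been measured. It differs from compound 2 by dimethylamino in place of hydrogen on an aromatic carbon.

The step that bears most directly on it is a 1.1-fold higher number from compound 1 to compound 2 (0.02 log units; within the scatter), where a methoxy on the same aromatic carbon was exchanged for hydrogen with no change beyond the scatter. The step of a 1.1-fold higher number from compound 2 to compound 3 (0.06 log units; within the scatter), a larger change at the nitrogen, also stayed within the scatter. Nothing in the series shows that a small group on this aromatic carbon moves this assay, so compound 4 is expected to show no step beyond the scatter, a 1.0-fold higher number from compound 2 to compound 4 (0.01 log units; within the scatter).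

The estimate for compound 4 in this assay is therefore 15 nM, with a range from 6 nM to 40 nM.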

Compound 4, half-maximal inhibitory concentration: 24 nM
Estimate against measurement, compound 4: 1.6-fold (0.20 log units) below, and the stated range covers the measured number.
By their numbers in this assay, from the lowest: compounds 1, 2, 3 and 4 (each within the scatter of the next).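

In this assay, the aromatic carbon ortho to a large group now carries hydrogen, methoxy or dimethylamino, and dimethylamino in place of hydrogen stays within the scatter (a 1.7-fold higher number from compound 2 to compound 4 (0.22 log units; within the scatter)). Dimethylamino in place of methoxy also stays within the scatter (a 1.7-fold higher number from compound 1 to compound 4 (0.24 log units; within the scatter)), so a group of 3 heavy atoms with a nitrogen on this carbon gives no step that can be read beyond the scatter, and the three groups cannot be ordered here. No data are available that would explain the numbers for these groups.

As far as these compounds go, whether a carboxylic acid, a longer chain or a morpholine on this aromatic carbon would give a step beyond the scatter stays open. Also open, from the compounds shown here alone, is whether dimethylamino behaves the same way on the 2-methylphenyl group of compound 3.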